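Swapping the Aryl Group: Trifluoromethyl to Ethoxycarbonyl

The source may report more compounds than this note shows. Statements on the series, on what has been measured and on what is new or still open speak of the compounds shown alone.

Three compounds share one core and differ only in the group on the outer benzene ring. Compound 1 `CC(C)(C)c1ccc(-c2cc(N3CCC(CCNS(N)(=O)=O)CC3)ncn2)cc1` carries a tert-butyl group and in a functional assay on MCF7 cells (Homo sapiens) for antiproliferative activity, read by sulforhodamine B assay, with a stated time of 48 h (on this read-out higher numbers stand for weaker inhibition of growth and lower numbers for stronger inhibition of growth), gives 13100 nM. Compound 2 `NS(=O)(=O)NCCC1CCN(c2cc(-c3ccc(Cl)cc3)ncn2)CC1` carries a chloro group and in this assay gives 19700 nM. Compound 3 `NS(=O)(=O)NCCC1CCN(c2cc(-c3ccc(C(F)(F)F)cc3)ncn2)CC1` carries a trifluoromethyl group and in this assay gives 15200 nM. None of the exchanges among them moves the number beyond the scatter: a 1.5-fold higher number from compound 1 to compound 2 (0.18 log units; within the scatter), a 1.2-fold higher number from compound 1 to compound 3 (0.06 log units; within the scatter) and a 1.3-fold lower number from compound 2 to compound 3 (0.11 log units; within the scatter). Compound 3 thus sits within the scatter of both others, nearest to compound 1 and furthest from compound 2.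

Compound 4 `CCOC(=O)c1ccc(-c2cc(N3CCC(CCNS(N)(=O)=O)CC3)ncn2)cc1` continues the series: ethoxycarbonyl in place of trifluoromethyl on an aromatic carbon. Among the compounds with values here, all three measured steps exchange the group at this same place, and each stays within the scatter, which is the only guide available. Within the data shown here, the new group brings two hydrogen-bond acceptors, something none of the measured groups had, so the range is kept wide. On this basis the expected step is a 1.0-fold lower number from compound 3 to compound 4 (0.01 log units; within the scatter), that is, no change beyond the scatter. Compound 4 is therefore estimated at 15000 nM, with a range from 6000 nM to 40000 nM.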

Compound 4, concentration for 50% growth inhibition: 6200 nM
Compound 4: the middle estimate sits 2.4-fold (0.38 log units) above what was measured; the range from low to high includes it.
By their numbers in this assay, from the lowest: compound 4; then compounds 1, 3 and 2 (each within the scatter of the next).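

Ethoxycarbonyl on this aromatic carbon gives a 2.5-fold lower number from compound 3 to compound 4 (0.39 log units; beyond the scatter) when it replaces trifluoromethyl, a 3.2-fold lower number from compound 2 to compound 4 (0.50 log units; beyond the scatter) when it replaces chloro and a 2.1-fold lower number from compound 1 to compound 4 (0.32 log units; beyond the scatter) when it replaces tert-butyl. Within the data shown here, the earlier exchanges all stayed within the scatter, so this is the first sign that the position responds to the group it carries in this assay and that compound 4 gives the strongest inhibition of growth of the four, although each step is only modest. Unlike trifluoromethyl, ethoxycarbonyl has hydrogen-bond acceptors and a double bond outside aromatic rings, but nothing available here shows whether either feature is responsible for the change or offers any other explanation for it.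

The compounds shown leave open whether the whole ethoxycarbonyl group is needed, since a carboxylic acid, a methoxycarbonyl group or a primary amide at the same place would help to show which part of it matters. They also leave open how far the trend extends, for example whether a longer chain on the ester oxygen, such as propoxycarbonyl, would give a still lower number or lose the gain.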